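Extending an azidopropyl arm to a chlorophenoxy chain

The source may report more compounds than this note shows. Statements on the series, on what has been measured and on what is new or still open speak of the compounds shown alone.

Measured compounds:
compound 1, `[N-]=[N+]=NCCCN1CCCC(COC(=O)c2ccccc2-c2ccccc2)C1`: 1820 nM
compound 2, `O=C(OCC1CCCN(CCCc2ccccc2)C1)c1ccccc1-c1ccccc1`: 100000000 nM; > 100000 nM (2 entries)
compound 3, `O=C(NCC1CCCN(CCCc2ccccc2)C1)c1ccccc1-c1ccccc1`: 100000000 nM

All three share one core, a ring bearing an amine nitrogen, with a biphenyl ester or amide hanging from the other side. Within the data shown here, in an in vitro functional assay on HEK ts201 cells for antagonist activity at Neuronal acetylcholine receptor; alpha3/beta4 (Homo sapiens), read by fluorescence and calcium flux (a higher number here means a weaker inhibitor, a lower number a stronger inhibitor), compound 1 gives 1820 nM, the lowest of the two numbers reported, and the only compound with a clear inhibitory number. Compound 3 in this assay gives 100000000 nM, a far higher number and well beyond the scatter. Compound 2 gives 100000000 nM; > 100000 nM (2 entries) in this assay, and the several entries of compound 2 in this assay, 100000000 nM; > 100000 nM (2 entries) gathers its several entries, all of them far above the number of compound 1.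

Compound 4, `O=C(OCC1CCCN(CCCCCOc2ccc(Cl)cc2)C1)c1ccccc1-c1ccccc1`, has not been measured. It differs from compound 1 by 2-(4-chlorophenoxy)ethyl in place of azido on a saturated chain carbon, three bonds along the chain from an amine nitrogen in a ring. Compound 2 already shows that swapping the azido arm for a chain ending in a plain phenyl ring takes the number out of range, and compound 4 carries an even longer aryl-bearing chain. A step to a weaker inhibitor, well beyond the scatter, is therefore expected, a 6.6-fold higher number from compound 1 to compound 4 (0.82 log units; beyond the scatter). The estimated value for compound 4 in this assay is 12000 nM, expected between 2500 nM and 100000 nM.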

Compound 4, half-maximal inhibitory concentration: 15500 nM
Beside the measured number, compound 4's estimate is 1.3-fold (0.11 log units) below it; the measured number falls inside the stated range.
By their numbers in this assay, from the lowest: compound 1; then compound 4; then compound 3.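

In this assay the change reads as an 8.5-fold higher number from compound 1 to compound 4 (0.93 log units; beyond the scatter), so inhibition weakens on this step, yet a readable number survives when the azido group gives way to the much larger 2-(4-chlorophenoxy)ethyl group. This shows that the position, on a saturated chain carbon, three bonds along the chain from an amine nitrogen in a ring, can carry an arm with a six-membered aromatic ring without all measurable inhibition being lost. Compound 2, whose chain ends in a plain phenyl ring, gives no such clear reading, and one of its entries is a limit of the assay: the several entries of compound 2 in this assay, 100000000 nM; > 100000 nM (2 entries)

The new arm brings a chlorine atom, an ether oxygen and an aromatic ring in a single change, so the compounds shown cannot say which of these parts accounts for the step or for the retained inhibition. As far as these compounds go, it also remains open how the number would move with a phenoxy chain lacking the chlorine, or with a chain ending in a simple amine or a carboxylic acid.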